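The source may hold more compounds than are shown below. What is called first, only, known or untested is meant among the compounds shown, and "the series" means these compounds.

Measured in an ADME assay on MT4 cells (Homo sapiens) for cytotoxicity, read by MTT assay; a higher number here means that more compound is tolerated, a lower number that less compound is tolerated:
- Compound 1 `Cc1cc(C)cc(S(=O)(=O)c2c(C(=O)Nc3ccc(O)cc3)[nH]c3ccc(Cl)cc23)c1`: 18100 nM
- Compound 2 `Cc1cc(C)cc(S(=O)(=O)c2c(C(=O)NCc3cc(O)ncn3)[nH]c3ccc(Cl)cc23)c1`: > 53000 nM, a limit

For the measured compounds named here, compound 1 holds the only actual number, 18100 nM, and the other result stands as the limit of > 53000 nM in this assay, at which 1 of the 2 values shown sits. Compound 3 `Cc1cc(C)cc(S(=O)(=O)c2c(C(=O)Nc3ccc(CO)cc3)[nH]c3ccc(Cl)cc23)c1` carries hydroxymethyl in place of hydroxy on an aromatic carbon. Going by the values given here, the one measured step, an at least 2.9-fold higher number from compound 1 to compound 2 (0.46 log units; beyond the scatter), exchanges the entire group on the amide-type nitrogen, so it bears only loosely on this smaller change. Little movement is therefore expected in this assay. The estimated step is a 1.2-fold higher number from compound 1 to compound 3 (0.08 log units; within the scatter), slightly upward at most and not expected to exceed the scatter. For compound 3 the expected value is 22000 nM, with an estimated range of 10000 nM to 50000 nM.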

Compound 3, half-maximal cytotoxic concentration: 39600 nM
Estimate against measurement, compound 3: 1.8-fold (0.26 log units) below; low and high end bracket the measured number.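

Compound 2 had changed the whole group on the amide-type nitrogen, whereas hydroxymethyl in place of hydroxy alters only the substituent on an aromatic carbon, para to a large group. In this assay even this small change moves the result, with a 2.2-fold higher number from compound 1 to compound 3 (0.34 log units; beyond the scatter). The other new comparison, which again exchanges the group on the amide-type nitrogen, is an at least 1.3-fold lower number from compound 2 to compound 3 (0.12 log units; that floor lies within the scatter). That step can be read no further than its floor, because compound 2 is known only as a limit: the limit of > 53000 nM in this assay, at which 1 of the 3 values shown sits.

The compounds shown leave open how an amine, a carboxylic acid or a longer chain at this position would compare with hydroxymethyl.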